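Amide ring size and hepatocyte clearance in the series

This account rests on a few compounds, and the source may have more. Where it says the series, first, only, none or still open, it means among the compounds named here.

Compound 3 `CC(C)n1cc(-c2ccnc3[nH]c(C4CCN(CC(=O)N5CCCCC5)CC4)cc23)ccc1=O` stands at the top of the three numbers seen so far in an ADME assay on cells (Hepatocyte, Rattus norvegicus) for metabolic stability (on this read-out lower numbers stand for slow clearance and higher numbers for fast clearance), where compound 3 gives 26 uL/min. Compound 1 `CC(C)n1cc(-c2ccnc3[nH]c(C4CCN(CC(=O)N5CCCC5)CC4)cc23)ccc1=O` gives 5.4 uL/min in this assay, and compound 2 `CN(C)C(=O)CN1CCC(c2cc3c(-c4ccc(=O)n(C5CCOCC5)c4)ccnc3[nH]2)CC1` gives 2.3 uL/min; both lie well under compound 3. Within the data shown here, the one step measured within the set is a 4.8-fold higher number from compound 1 to compound 3 (0.68 log units; beyond the scatter), so enlarging the amide ring raised the number beyond the scatter.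

Compound 4 `CC(C)n1cc(-c2ccnc3[nH]c(C4CCN(CC(=O)N(C)C)CC4)cc23)ccc1=O` is the next point. The change from compound 3 is dimethylamino in place of piperidin-1-yl on a carbonyl carbon. Among the measured compounds shown here, no measured step covers this exact exchange; the only related evidence is that the smaller pyrrolidin-1-yl amide of compound 1 read lower than the piperidin-1-yl amide of compound 3 in this assay, and that compound 2 reads lowest of all. On that basis the expected direction for compound 4 is downward, with a step of a 4.7-fold lower number from compound 3 to compound 4 (0.67 log units; beyond the scatter) expected. The estimate for compound 4 in this assay is 5.5 uL/min, expected to fall between 2.2 uL/min and 13 uL/min.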

Compound 4, intrinsic clearance in a liver preparation (reported as CLH), per the amount of preparation that the assay uses in the Hepatocyte assay: 2.3 uL/min
The estimate for compound 4 lay 2.4-fold (0.38 log units) above the measured number; low and high end bracket the measured number.
By their numbers in the Hepatocyte assay, from the lowest: compounds 2 and 4 (each within the scatter of the next); then compound 1; then compound 3.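

In the Hepatocyte assay the open-chain amide goes further than the smaller ring did, with an 11-fold lower number from compound 3 to compound 4 (1.05 log units; beyond the scatter) and also a 2.3-fold lower number from compound 1 to compound 4 (0.37 log units; beyond the scatter), so dimethylamino on the carbonyl carbon reads below both ring amides. On the aromatic nitrogen the series shows no change at the digits printed from compound 2 to compound 4 (within the scatter), so isopropyl and oxan-4-yl cannot be told apart on this read-out when each is paired with a small amide. In a physicochemical assay for lipophilicity, using the shake flask method, measured as octanol-water partition, at pH 7.4 (a lower number here means a more polar compound, a higher number a more lipophilic compound), compound 3 gives 2.8 and compound 4 gives 1.9, and the lower clearance number of compound 4 may follow from its lower lipophilicity: the measured distribution coefficient of compound 3, 2.8, and of compound 4, 1.9, a number 0.90 log units lower (beyond the scatter).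

As far as these compounds go, whether a morpholin-4-yl amide, with an oxygen in the ring, would read as low as dimethylamino stays open. So does the reading of a longer chain on the amide nitrogen, such as diethylamino.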